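Swapping to 3,5-dichlorophenyl on the core of compound 1

The compounds below may be only part of what the source reports. "The series", "measured", "known", "first", "only" and "open" are said of these compounds alone.

Among the compounds with values here, in a functional assay on MCF7 cells (Homo sapiens) for antiproliferative activity, read by MTT assay, with a stated time of 48 h (on this read-out lower numbers stand for stronger inhibition and higher numbers for weaker inhibition), compound 1 `O=C(/C=C/c1ccccc1)Nc1cc2c(Nc3ccc(F)c(Cl)c3)ncnc2s1` gives 14300 nM, the lower of the two numbers measured so far. Compound 2 `O=C(/C=C/c1ccccc1)Nc1cc2ncnc(Nc3ccc(F)c(Cl)c3)c2s1`, built on a different core, gives 30900 nM. Compound 3 `O=C(/C=C/c1ccccc1)Nc1cc2ncnc(Nc3cc(Cl)cc(Cl)c3)c2s1` shares the core of compound 2. Compound 3 gives > 100000 nM, which is a limit of the assay.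

Compound 4 `O=C(/C=C/c1ccccc1)Nc1cc2c(Nc3cc(Cl)cc(Cl)c3)ncnc2s1` keeps the core of compound 1 and differs from it as follows: 3,5-dichlorophenyl in place of 3-chloro-4-fluorophenyl on a nitrogen on an aromatic ring. This places 3,5-dichlorophenyl where 3-chloro-4-fluorophenyl stood, on a nitrogen on an aromatic ring. Within the data shown here, the only measured step that bears on this change is the same exchange on the other core, an at least 3.2-fold higher number from compound 2 to compound 3 (0.51 log units; beyond the scatter). As far as these compounds go, that single step comes from a different core, so its transfer to the core of compound 1 remains untested. A move to a higher number in this assay is still expected, of similar size or somewhat larger. The expected step is a 3.8-fold higher number from compound 1 to compound 4 (0.59 log units; beyond the scatter). The estimated value for compound 4 is 55000 nM, with an expected range of 24000 nM to 120000 nM.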

Compound 4, half-maximal inhibitory concentration: 5800 nM
Beside the measured number, compound 4's estimate is 9.5-fold (0.98 log units) above it; the whole stated range lies above it.
By their numbers in this assay, from the lowest: compound 4; then compound 1; then compound 2. At a limit, above all of these: compound 3.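

In this assay, 3,5-dichlorophenyl in place of 3-chloro-4-fluorophenyl on a nitrogen on an aromatic ring gives a 2.5-fold lower number from compound 1 to compound 4 (0.39 log units; beyond the scatter), so this exchange lowers the number on this core. The direction of the exchange therefore differs between the two cores, and a step read on one core does not carry over to the other: the same change on two cores in this assay, an at least 3.2-fold higher number (0.51 log units; beyond the scatter) from compound 2 to compound 3 and a 2.5-fold lower number (0.39 log units; beyond the scatter) from compound 1 to compound 4, at least 7.9-fold (0.90 log units) apart, beyond the scatter of two such steps. Compound 3 stands at a limit, so the step on the other core has a known minimum but no exact size: the limit of > 100000 nM in this assay, at which 1 of the 4 values shown sits.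

As far as these compounds go, it remains open whether a bromophenyl or a methoxyphenyl group on the same nitrogen would also separate the two cores in this way. From the compounds shown here alone, with one pair per core, it also remains open how general the difference between the cores is.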